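A few compounds are considered here, and "the series" means these few. Any claim that something is new, unique, unknown or untested is made for them only; others in the source may bear on it.

Measured in a functional assay on A-375 cells (Homo sapiens) for inhibition, read by sulforhodamine B assay, with a stated time of 6 days; on this read-out lower numbers stand for stronger inhibition and higher numbers for weaker inhibition:
Compound 1 `CNCCNCc1cccc(-c2nc(NC3CCOCC3)c(C)c(-c3ccnc4[nH]ccc34)n2)c1`: 18200 nM
Compound 2 `CNCCNCc1cccc(-c2nc(NC3CCOCC3)c(C)c(-c3cncnc3)n2)c1`: > 50000 nM

Compound 2 gives only a limit of the assay, > 50000 nM, and no number. Compound 3 `CNCCNCc1cccc(-c2nc(NC3CCOCC3)c(C)c(-c3cn(C)nc3C)n2)c1` is reached by 1,3-dimethyl-1H-pyrazol-4-yl in place of pyrimidin-5-yl on an aromatic carbon, with 1,3-dimethyl-1H-pyrazol-4-yl in place of pyrimidin-5-yl on an aromatic carbon ortho to a methyl group. Going by the values given here, one measured step bears on this place: an at least 2.7-fold higher number from compound 1 to compound 2 (0.43 log units; beyond the scatter), a change at the same carbon. That step shows that the group here can move the read-out, but its size is open-ended, and compound 2 offers no firm starting number. Only a small move towards lower numbers in this assay is therefore expected, and compound 3 may well remain at the limit. The expected step is an at least 1.4-fold lower number from compound 2 to compound 3 (0.15 log units; that floor lies within the scatter). For compound 3 the estimated value is 35000 nM, with an expected range from 15000 nM to 70000 nM.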

Compound 3, half-maximal inhibitory concentration: > 50000 nM
Compound 3: only a limit was reported (the forecaster's own chance of this, stated with the estimate: 50%); middle value at least 1.4-fold (0.15 log units) from the limit.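

In this assay, compound 3 gives only a limit of the assay, > 50000 nM. At this carbon, a second replacement of the larger two-ring group, now by 1,3-dimethyl-1H-pyrazol-4-yl, gives an at least 2.7-fold higher number from compound 1 to compound 3 (0.43 log units; beyond the scatter), so a five-membered aromatic ring with 2 hetero atoms does not hold the read-out near the value of the larger group either. The step between compound 2 and compound 3 cannot be read, and pyrimidin-5-yl and 1,3-dimethyl-1H-pyrazol-4-yl cannot be ranked, because both compounds sit at one boundary: the limit of > 50000 nM in this assay, at which 2 of the 3 values shown sit.

The compounds shown leave open whether a plain phenyl or a pyridin-4-yl group on this carbon would bring the number back towards that of compound 1, 18200 nM. They also leave open whether an ethyl group in place of the methyl group would shift the read-out with 1,3-dimethyl-1H-pyrazol-4-yl in place.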